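Hydroxy to methoxy on the shared core: compound 4

The source may report more compounds than this note shows. Statements on the series, on what has been measured and on what is new or still open speak of the compounds shown alone.

Measured so far in a functional assay on PBMC cells (Homo sapiens) for inhibition, read by scintillation counting and thymidine incorporation, with a stated time of 3 days, tested at 100 uM; on this read-out lower numbers stand for less inhibition and higher numbers for more inhibition at the one concentration tested (going by the name of the read-out):
compound 1 `COc1cc([C@@H]2c3cc(OC)c(O)cc3C(=O)[C@@H](C)[C@H]2C)ccc1O` gives 59.7%
compound 2 `COc1cc([C@@H]2c3cc(O)c(OC)cc3C(=O)[C@@H](C)[C@H]2C)ccc1O` gives 56.9%
compound 3 `COc1cc2c(cc1O)C(=O)[C@@H](C)[C@@H](C)[C@@H]2c1ccc(OC)c(OC)c1` gives 54.1%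

Compound 2 sits in the middle of these three numbers, but its gaps to compound 3 and to compound 1 are each within the scatter, so the three cannot be told apart on this assay.

Compound 4 `COc1cc([C@@H]2c3cc(OC)c(OC)cc3C(=O)[C@@H](C)[C@H]2C)ccc1O` is not yet measured. It differs from compound 2 by methyl in place of hydrogen on an oxygen on an aromatic ring. Among the compounds with values here, one measured step bears on this change: a number 5.6 percentage points lower from compound 1 to compound 3 (within the scatter), a shift within the scatter. On that basis the step from compound 2 to compound 4 is expected to be small, with no direction beyond the scatter; the estimate is a number 3.9 percentage points lower from compound 2 to compound 4 (within the scatter). Compound 4 is estimated at 53%, between 42% and 64%.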

Compound 4, a percentage reported as inhibition, at one concentration (the size of the read-out at that concentration, not a potency): 61%
The estimate for compound 4 lay 8 percentage points below the measured number; the measured number falls inside the stated range.
By their numbers in this assay, from the lowest: compounds 3, 2, 1 and 4 (each within the scatter of the next).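

Methyl in place of hydrogen on an oxygen on an aromatic ring now reads on two further pairs in this assay: a number 4.1 percentage points higher from compound 2 to compound 4 (within the scatter), and a number 1.3 percentage points higher from compound 1 to compound 4 (within the scatter). Replacing either hydroxy that compound 4 carries as methoxy therefore leaves the number unresolved from that of its parent. The change shows no direction that holds across the shared core: the same change on two cores in this assay, a number 5.6 percentage points lower (within the scatter) from compound 1 to compound 3 and a number 4.1 percentage points higher (within the scatter) from compound 2 to compound 4, 9.7 percentage points apart, within the scatter of two such steps

On these data alone, whether a longer chain on this oxygen, such as ethyl or benzyl, or an amine in place of the hydroxy would move the number remains open. Potency also remains open, as the read-out covers one concentration only.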